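A Methyl Added to the Phenyl of Compound 1

A few compounds are considered here, and "the series" means these few. Any claim that something is new, unique, unknown or untested is made for them only; others in the source may bear on it.

Measured in a functional assay on A549 cells (Homo sapiens) for antiproliferative activity, with a stated time of 5 days; a higher number here means a weaker inhibitor, a lower number a stronger inhibitor:
- compound 1 `CC1OC2(C=CC(=O)C=C2)N(c2nc(-c3ccc4ccccc4c3)nn2-c2ccccc2)C1=O`: 310 nM
- compound 2 `CC1OC2(C=CC(=O)C=C2)N(c2nc(-c3cccc4ccccc34)nn2-c2ccccc2)C1=O`: 180 nM
- compound 3 `Cc1ccccc1-n1nc(-c2cccc3ccccc23)nc1N1C(=O)COC12C=CC(=O)C=C2`: 130 nM

Compound 1 gives 310 nM, level within the scatter with compound 2, while the number for compound 3 lies lower, beyond the scatter. The next compound, compound 4 `Cc1ccc(-n2nc(-c3ccc4ccccc4c3)nc2N2C(=O)C(C)OC23C=CC(=O)C=C3)cc1`, has methyl in place of hydrogen on an aromatic carbon, para to a large group, turning phenyl into 4-methylphenyl: methyl in place of hydrogen on an aromatic carbon.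

For the measured compounds named here, the only measured single-place step is a 1.7-fold lower number from compound 1 to compound 2 (0.24 log units; within the scatter), and it concerns the naphthalene attachment, not this methyl. Compound 3, at 130 nM, also carries a methyl on that aromatic ring, but it differs from compound 1 in other places too, so it offers only a weak hint. Going by the values given here, no measured step isolates the methyl, so no shift beyond the scatter is expected in this assay. The estimated change is a 1.1-fold lower number from compound 1 to compound 4 (0.06 log units; within the scatter), and this is expected to stay within the scatter. Compound 4 is expected at 270 nM, with an estimated range of 110 nM to 620 nM.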

Compound 4, half-maximal inhibitory concentration: 1210 nM
The estimate for compound 4 lay 4.5-fold (0.65 log units) below the measured number, outside the stated range (above it).
By their numbers in this assay, from the lowest: compounds 3, 2 and 1 (each within the scatter of the next, the first and the last beyond it); then compound 4.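

In this assay, for the compounds shown here, the change from phenyl to 4-methylphenyl gives a 3.9-fold higher number from compound 1 to compound 4 (0.59 log units; beyond the scatter), making it the only single-place step here that lies beyond the scatter, while the naphthalene step gives a 1.7-fold lower number from compound 1 to compound 2 (0.24 log units; within the scatter) and stays within it. This shows that a position para to a large group on this aromatic ring is not indifferent to a single added carbon, and that the methyl here moves the compound towards weaker inhibition. Nothing available explains this shift.

The compounds shown leave open whether a chlorine, a methoxy or an amine at the same place would cost as much as the methyl, or whether any addition there does. They also leave open whether the same methyl would have a similar effect on compound 2, which carries naphthalen-1-yl.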